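Cell tolerance on swapping pyridin-3-yl for a pyridinylethynyl group

The compounds below may be only part of what the source reports. "The series", "measured", "known", "first", "only" and "open" are said of these compounds alone.

Compound 1 `CNC(=O)[C@@H](NC(=O)[C@](O)(CCCN(Cc1ccc(Br)cc1)NC(=O)[C@@H](NC(=O)OC)C(C)(C)C)Cc1ccccc1)C(C)(C)C` gives > 10000 nM as a limit.
Compound 2 `CNC(=O)[C@@H](NC(=O)[C@@](CCCN(Cc1ccc(Br)cc1)NC(=O)[C@@H](NC(=O)OC)C(C)(C)C)(Cc1ccccc1)[Si](C)(C)C(C)(C)C)C(C)(C)C` gives > 10000 nM as a limit.
Compound 3 `CNC(=O)[C@@H](NC(=O)[C@@](O)(CCCN(Cc1ccc(-c2cccnc2)cc1)NC(=O)[C@@H](NC(=O)OC)C(C)(C)C)Cc1ccccc1)C(C)(C)C` gives > 50000 nM as a limit.

All three readings come from an ADME assay on MT4 cells (Homo sapiens) for cytotoxicity, read by XTT assay, with a stated time of 5 days (a higher number here means that more compound is tolerated, a lower number that less compound is tolerated), and none of them is an exact number. Compound 3 stands at > 50000 nM as a limit, and so no true value is known for it. Among the measured compounds shown here, with only limits in hand, no measured step is available to size a structural change.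

Compound 4 `CNC(=O)[C@@H](NC(=O)[C@@](O)(CCCN(Cc1ccc(C#Cc2ccccn2)cc1)NC(=O)[C@@H](NC(=O)OC)C(C)(C)C)Cc1ccccc1)C(C)(C)C` differs from compound 3 in one place: 2-(pyridin-2-yl)ethynyl in place of pyridin-3-yl on an aromatic carbon with 2-(pyridin-2-yl)ethynyl in place of pyridin-3-yl on an aromatic carbon.

In this assay no step beyond the usual scatter is expected, and any drift would more likely be downward than upward. The estimated change is an at least 1.4-fold lower number from compound 3 to compound 4 (0.15 log units; that floor lies within the scatter) and rests only on the limit of compound 3. For compound 4 the expected half-maximal cytotoxic concentration is 35000 nM within an estimated range of 10000 nM to 60000 nM. For compound 4, too, a limit rather than an exact number is expected.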

Compound 4, half-maximal cytotoxic concentration: > 50000 nM
Compound 4: no number, only a limit; the forecaster's own chance of this, stated with the estimate: 75%; middle value at least 1.4-fold (0.15 log units) from the limit.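

In this assay, among the compounds shown here, no step from compound 3 to compound 4 can be read, because both compounds give the same limit and not a number: the limit of > 50000 nM in this assay, at which 2 of the 4 values shown sit.

From the compounds shown here alone, it remains open whether 2-(pyridin-2-yl)ethynyl in place of pyridin-3-yl changes the half-maximal cytotoxic concentration at all.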